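Swapping the Amide Cyclohexyl for a 2-Fluorobenzyl Group

The source may report more compounds than this note shows. Statements on the series, on what has been measured and on what is new or still open speak of the compounds shown alone.

In a functional assay on QGY7701 cells (Homo sapiens) for cytotoxicity, read by MTT assay, with a stated time of 24 h (on this read-out higher numbers stand for weaker inhibition and lower numbers for stronger inhibition), compound 1 `C=CC1=C(C(=O)NC2CCCCC2)C(c2ccc(OC)c(OC)c2)OC1` gives 7490 nM. Compound 2 `C=CC1=C(C(=O)NC2CCCCC2)C(c2ccc(OC)cc2)OC1` reports > 100000 nM, which is a limit of this assay rather than a number, the point described as the limit of > 100000 nM in this assay, at which 1 of the 3 values shown sits. Compound 3 `C=CC1=C(C(=O)NC2CCCCC2)C(c2ccc(F)cc2)OC1` gives 40500 nM. The two measured steps, an at least 13-fold higher number from compound 1 to compound 2 (1.12 log units; beyond the scatter) and an at least 2.4-fold lower number from compound 2 to compound 3 (0.39 log units; beyond the scatter), both concern the aryl ring, so compound 2 carries the highest number of the three.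

Compound 4 `C=CC1=C(C(=O)NCc2ccccc2F)C(c2ccc(OC)cc2)OC1` differs from compound 2 by 2-fluorobenzyl in place of cyclohexyl on an amide-type nitrogen. Neither measured step touches the amide substituent, so none of them indicates the size or direction of the step in this assay from compound 2 to compound 4. With compound 2 known only as a limit, the estimate for compound 4 is 100000 nM, ranging from 20000 nM to 300000 nM. The expected step is a number no higher from compound 2 to compound 4 (the limit leaves the size open).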

Compound 4, half-maximal inhibitory concentration: > 100000 nM
Compound 4 ended at the assay's limit (the forecaster's own chance of this, stated with the estimate: 60%); the middle value lies on the limit itself.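

Among these compounds, compound 4, at > 100000 nM, is a limit and not a number, as is the value of compound 2, so no step between compound 2 and compound 4 can be read: the limit of > 100000 nM in this assay, at which 2 of the 4 values shown sit.

The compounds shown leave open whether 2-fluorobenzyl in place of cyclohexyl on the amide-type nitrogen changes the number at all.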